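A New Ring on the Ether Oxygen of Compound 1

A few compounds are considered here, and "the series" means these few. Any claim that something is new, unique, unknown or untested is made for them only; others in the source may bear on it.

Compound 1 `CCOC(=O)c1c(C)noc1OCC(=O)[C@H](CC(=O)O)NC(=O)[C@@H](NC(=O)COc1cccc2ccccc12)C(C)C` was tested in a functional assay on Jurkat cells (Homo sapiens) for inhibition; a lower number here means a stronger inhibitor, a higher number a weaker inhibitor. In this assay compound 1 gives > 200000 nM, which is a limit of the assay and not a number. Compound 2 `CC(C)[C@H](NC(=O)COc1cccc2ccccc12)C(=O)N[C@@H](CC(=O)O)C(=O)COn1nnc2ccccc21` differs from compound 1 in one place. In this assay compound 2 gives > 200000 nM, again a limit. The step that the two limits leave unreadable from compound 1 to compound 2 therefore has no readable size, as both values sit at the limit of > 200000 nM in this assay, at which 2 of the 2 values shown sit. Compound 3 `CC(C)[C@H](NC(=O)COc1cccc2ccccc12)C(=O)N[C@@H](CC(=O)O)C(=O)COc1ccnc(C(F)(F)F)n1` is not yet measured. It differs from compound 1 as follows: 2-(trifluoromethyl)pyrimidin-4-yl in place of 4-(ethoxycarbonyl)-3-methyl-1,2-oxazol-5-yl on an oxygen on a saturated carbon. Among the compounds with values here, the only measured step touches the same oxygen on a saturated carbon, but its size is unreadable, so neither a direction nor a size can be drawn from it. Compound 3 is expected to stay near the limit, the step of an at least 1.3-fold lower number from compound 1 to compound 3 (0.12 log units; that floor lies within the scatter) being an estimate only. Compound 3 is estimated at 150000 nM, within a range from 20000 nM to 500000 nM.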

Compound 3, half-maximal inhibitory concentration: 37000 nM
For compound 3 the middle estimate is 4.1-fold (0.61 log units) above the measured one, and the stated range covers the measured number.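

What Compound 3 Adds at This Oxygen

This oxygen on a saturated carbon can carry a group that gives a readable number in this assay, and 2-(trifluoromethyl)pyrimidin-4-yl is the only group shown that does so. Against the two other groups the steps are an at least 5.4-fold lower number from compound 1 to compound 3 (0.73 log units; beyond the scatter) and an at least 5.4-fold lower number from compound 2 to compound 3 (0.73 log units; beyond the scatter). Both are floors and not full sizes, because compound 1 and compound 2 each stand at a limit of the assay: the limit of > 200000 nM in this assay, at which 2 of the 3 values shown sit.

On these data alone, whether the lower number goes with the pyrimidine ring or with the trifluoromethyl group stays open, as compound 3 brings both at once. A pyrimidin-4-yl group with a methyl in place of trifluoromethyl, or a phenyl ring carrying trifluoromethyl, would separate the two.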